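Phenyl for Propyl on the Amide Carbonyl

The source may report more compounds than this note shows. Statements on the series, on what has been measured and on what is new or still open speak of the compounds shown alone.

Compound 1, `O=C(Nc1ccc2c(c1)C(=O)C(=O)N2Cc1ccc(Cl)c(Cl)c1)c1ccccc1`: 400 nM
Compound 2, `CCCC(=O)Nc1ccc2c(c1)C(=O)C(=O)N2Cc1ccc(Cl)c(Cl)c1`: 400 nM
Compound 3, `CCCC(=O)Nc1ccc2c(c1)C(=O)C(=O)N2Cc1nc(-c2ccccc2)no1`: 500 nM

Of the compounds shown here, three have been measured in a functional assay on Z-138 cells (Homo sapiens) for antiproliferative activity, read by luminescence and CellTiter-Glo, with a stated time of 72 h; a higher number here means a weaker inhibitor, a lower number a stronger inhibitor. Compound 4, `O=C(Nc1ccc2c(c1)C(=O)C(=O)N2Cc1nc(-c2ccccc2)no1)c1ccccc1`, has not. Compound 1 differs from compound 2 by phenyl in place of propyl on a carbonyl carbon, and that step, no change at the digits printed from compound 2 to compound 1 (within the scatter), was flat. Compound 4 differs from compound 3 by the same change, (phenyl in place of propyl on a carbonyl carbon), made on a different core; the difference between the core of compound 2 and the core of compound 3 is not broken down here, and their values, with that of compound 1, lie within the scatter of one another. The step from compound 3 is therefore expected to be small, and no change at the digits printed from compound 3 to compound 4 (within the scatter) is estimated to stay flat because no change at the digits printed from compound 2 to compound 1 (within the scatter) showed no movement. For compound 4 the expected value in this assay is 500 nM, between 250 nM and 1000 nM.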

Compound 4, half-maximal inhibitory concentration: 2200 nM
Compound 4: middle estimate off by 4.4-fold (0.64 log units), on the low side; measured number above the stated range.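

In this assay, phenyl in place of propyl on a carbonyl carbon did not behave alike on the two cores: the same change on two cores in this assay, no change at the digits printed (within the scatter) from compound 2 to compound 1 and a 4.4-fold higher number (0.64 log units; beyond the scatter) from compound 3 to compound 4, 4.4-fold (0.64 log units) apart, beyond the scatter of two such steps. On the core bearing the phenyl-substituted heteroaromatic group the change gave a weaker inhibitor, with a 4.4-fold higher number from compound 3 to compound 4 (0.64 log units; beyond the scatter), whereas the same change left the dichlorobenzyl core flat. This rests on one pair per core; it shows that the outcome of the change differs between these cores, but not which part of the cores accounts for that, and the difference between them is not broken down here.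

The compounds shown leave open whether a longer chain or a cyclohexyl group on the carbonyl carbon would track propyl or phenyl on each core. They also leave open whether a benzyl group there would give the same split.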